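From compound 2 to compound 4: adding chloro

The source may report more compounds than this note shows. Statements on the series, on what has been measured and on what is new or still open speak of the compounds shown alone.

In an ADME assay on Huh-7 cells (Homo sapiens) for cytotoxicity (a lower number here means that less compound is tolerated, a higher number that more compound is tolerated), compound 2 `O=C(c1nc2scc(C3CC3)n2c1Cl)N1CCN(C2CCCC2)C(=O)C1` gives > 10000 nM, which is a limit of the assay. Compound 1 `O=C(c1nc2sccn2c1Cl)N1CCN(C2CCCC2)C(=O)C1` also stands at a limit, > 10000 nM. Compound 3 `CC(C)Cc1csc2nc(C(=O)N3CCN(C4CCCC4)C(=O)C3)c(Cl)n12` likewise stands at a limit, > 10000 nM. Compound 4 `O=C(c1nc2sc(Cl)c(C3CC3)n2c1Cl)N1CCN(C2CCCC2)C(=O)C1` differs from compound 2 by chloro in place of hydrogen on an aromatic carbon. The nearest measured changes are a step that the two limits leave unreadable from compound 1 to compound 2, a step that the two limits leave unreadable from compound 1 to compound 3 and a step that the two limits leave unreadable from compound 2 to compound 3, and none of them involves chloro. Compound 1, compound 2 and compound 3 all share (the limit of > 10000 nM in this assay, at which 3 of the 3 values shown sit), so no direction can be read from them. The estimated change is a step that the limit leaves unreadable from compound 2 to compound 4, expected to stay within the scatter. Compound 4 is expected at 12000 nM, with a range of 5000 nM to 30000 nM.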

Compound 4, half-maximal cytotoxic concentration: > 10000 nM
Compound 4: a limit, no number (the forecaster's own chance of this, stated with the estimate: 80%); the middle value does not contradict the limit.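

Compound 2 and compound 4 both stand at a limit in this assay, so the step from hydrogen to chloro cannot be read: the limit of > 10000 nM in this assay, at which 4 of the 4 values shown sit.

The compounds shown leave open at what concentration compound 1, compound 2, compound 3 or compound 4 becomes cytotoxic, and whether chloro, cyclopropyl or isobutyl changes it.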